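This account rests on a few compounds, and the source may have more. Where it says the series, first, only, none or still open, it means among the compounds named here.

Compound 1 `CSc1ccc(NC(=O)Nc2cc(C)nc3ccccc23)cc1` | 24000 nM
Compound 2 `Cc1cc(NC(=O)Nc2ccccc2C(C)(C)C)c2ccccc2n1` | > 25000 nM (a limit)
Compound 3 `Cc1cc(NC(=O)Nc2cc(F)cc(F)c2)c2ccccc2n1` | > 25000 nM (a limit)

Among the measured compounds shown here, in an ADME assay on HEK293 cells (Homo sapiens) for cytotoxicity, with a stated time of 72 h (a lower number here means that less compound is needed, a higher number that more compound is needed for the effect), compound 1 gives 24000 nM, the only true number among the measured compounds. Compound 2 reaches only a limit of the assay, not a number. Compound 3 likewise reaches only a limit. The data thus show (the limit of > 25000 nM in this assay, at which 2 of the 3 values shown sit), and compound 1 lies close to that same limit.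

The next compound to be tested is compound 4 (`Cc1cc(NC(=O)Nc2ccc(C(F)(F)F)cc2)c2ccccc2n1`), which differs from compound 1 in one place. It carries trifluoromethyl in place of methylsulfanyl on an aromatic carbon, para to a large group (trifluoromethyl in place of methylsulfanyl on an aromatic carbon).

For the measured compounds named here, no pair of measured compounds shows what a single change of this kind does, so any forecast is uncertain. The best anchor is compound 1 at 24000 nM, and no step beyond the usual scatter is expected in this assay. The expected change is a 1.0-fold higher number from compound 1 to compound 4 (0.02 log units; within the scatter). A result reported only as a limit would therefore be no surprise. For compound 4 the estimated value is 25000 nM, with an expected range from 12000 nM to 40000 nM.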

Compound 4, half-maximal effective concentration: 25000 nM
Beside the measured number, compound 4's estimate shows no gap at the digits printed; low and high end bracket the measured number.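

In this assay, putting trifluoromethyl in place of methylsulfanyl on an aromatic carbon, para to a large group, gives a 1.0-fold higher number from compound 1 to compound 4 (0.02 log units; within the scatter). This is the first pair among the compounds shown that differs in one place only, so it gives the first direct reading of a change at this position: a larger group without a counted hydrogen-bond acceptor replaces a smaller one with such an acceptor, and the number stays within the scatter. The reading comes from the top of the measurable range, however, so little room remains to see a higher number, and a further rise would appear as a limit rather than as a number: the limit of > 25000 nM in this assay, at which 2 of the 4 values shown sit.

Compound 2 and compound 3 differ from compound 1 and compound 4 in more than one place, so no steps can be read for them, and the effect of their ring substituents stays unresolved. As far as these compounds go, it also remains open whether a very different group at the same position, such as an amine or a carboxylic acid, would give a clearly lower number in this assay.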